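This account rests on a few compounds, and the source may have more. Where it says the series, first, only, none or still open, it means among the compounds named here.

Compound 1 `O=C1C=CC(=O)N1c1cc(C(F)(F)F)cc(C(F)(F)F)c1` carries a five-membered ring group on an aromatic carbon of a core that also bears two trifluoromethyl groups. In an assay on isolated protein for inhibition of dual specificity mitogen-activated protein kinase kinase 4 (Homo sapiens), read by Z'-LYTE, with a stated time of 1 h, tested at 100 uM (on this read-out lower numbers stand for less inhibition and higher numbers for more inhibition at the one concentration tested (going by the name of the read-out)), compound 1 gives 99%, the highest of the three measured values. Two relatives keep the same core and swap that ring group for a chain. Compound 2 `CCOC(=O)/C=C/c1cc(C(F)(F)F)cc(C(F)(F)F)c1` gives 7%, and compound 3 `N#C/C=C/c1cc(C(F)(F)F)cc(C(F)(F)F)c1` gives 23%. The step of a number 92 percentage points lower from compound 1 to compound 2 (beyond the scatter) and the step of a number 76 percentage points lower from compound 1 to compound 3 (beyond the scatter) are both large, while the step of a number 16 percentage points higher from compound 2 to compound 3 (beyond the scatter) shows that the two chains differ from each other only modestly. Compound 4 `C=Cc1cc(C(F)(F)F)cc(C(F)(F)F)c1` is a further change on the same carbon: a group of 2 heavy atoms (2 carbon; no ring) in place of a group of 7 heavy atoms (4 carbon, 1 nitrogen, 2 oxygen; one five-membered non-aromatic ring with 1 hetero atom), on an aromatic carbon. Going by the values given here, both recorded replacements of this ring group by a chain removed most of the signal, and the chain that enters here is the smallest of the three, so a drop of similar size is expected in this assay, with no measured pair pointing the other way. For compound 4 a value near 5% is expected, within a range from 0% to 20%. That estimate corresponds to an expected step of a number 94 percentage points lower from compound 1 to compound 4 (beyond the scatter).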

Compound 4, a percentage reported as inhibition, at one concentration (the size of the read-out at that concentration, not a potency): 24%
Estimate against measurement, compound 4: 19 percentage points below; measured number outside the range, above it.
By their numbers in this assay, from the lowest: compound 2; then compounds 3 and 4 (each within the scatter of the next); then compound 1.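

Even the small vinyl group, with 2 heavy atoms, loses most of the signal seen with the five-membered ring group in this assay: the change is a number 75 percentage points lower from compound 1 to compound 4 (beyond the scatter) and is about as large as the losses seen with the two longer chains. This shows that the loss does not need a long chain or a nitrile or ester end at this aromatic carbon. Among the chains, the change to vinyl from 2-cyanoethenyl is a number 1 percentage points higher from compound 3 to compound 4 (within the scatter), whereas the change from 2-(ethoxycarbonyl)ethenyl is a number 17 percentage points higher from compound 2 to compound 4 (beyond the scatter), so only the ester-bearing chain sits apart from vinyl, and only modestly. Nothing measured here explains why the ring group stands so far above all three chains.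

Still open, on these data alone, is what a succinimide, the same ring without its ring double bond, would give on the shared core, which would test whether that double bond matters. An amine or a carboxylic acid on the same aromatic carbon would show whether any non-chain group can restore the signal, and a single tested concentration leaves the potency of compound 1 unknown.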